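This account rests on a few compounds, and the source may have more. Where it says the series, first, only, none or still open, it means among the compounds named here.

In a functional assay on MCF7 cells (Homo sapiens) for cytotoxicity, read by MTT assay, with a stated time of 72 h (on this read-out higher numbers stand for weaker inhibition and lower numbers for stronger inhibition), compound 1 `COc1cccc(/C=C2\CCC/C(=C\c3ccc(Cl)cc3)C2=O)c1OC` gives 10300 nM. Compound 2 `COc1cccc(/C=C2\CCC/C(=C\c3ccccc3Br)C2=O)c1OC` is made from it by 2-bromophenyl in place of 4-chlorophenyl on a double-bonded chain carbon bound to a double-bonded ring carbon, and in this assay compound 2 gives 9700 nM. The step of a 1.1-fold lower number from compound 1 to compound 2 (0.03 log units; within the scatter) is therefore small. Compound 3 `COc1ccc(/C=C2\CCC/C(=C\c3ccc(Cl)cc3)C2=O)cc1OC` carries the same atoms as compound 1 joined differently; the difference between the two cores is not broken down here. In this assay compound 3 gives 6300 nM, the lowest of the three numbers, though its gaps to compound 2 and compound 1 both lie within the scatter, so no order among them can be claimed.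

Compound 4 `COc1ccc(/C=C2\CCC/C(=C\c3ccccc3Br)C2=O)cc1OC` has not yet been measured. It stands to compound 3 as compound 2 stands to compound 1: it is made by 2-bromophenyl in place of 4-chlorophenyl on a double-bonded chain carbon bound to a double-bonded ring carbon, the same change at the same place. Because the earlier step of a 1.1-fold lower number from compound 1 to compound 2 (0.03 log units; within the scatter) was hardly a change at all, the step from compound 3 to compound 4 is expected to be about as small, a 1.1-fold lower number from compound 3 to compound 4 (0.03 log units; within the scatter). On that basis compound 4 is estimated to give 5900 nM in this assay, most likely between 3000 nM and 12000 nM.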

Compound 4, half-maximal inhibitory concentration: 9500 nM
The estimate for compound 4 lay 1.6-fold (0.21 log units) below the measured number; the measured number falls inside the stated range.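

On the core of compound 3, 2-bromophenyl in place of 4-chlorophenyl gives a 1.5-fold higher number from compound 3 to compound 4 (0.18 log units; within the scatter) in this assay and so remains a small step, as it was on the core of compound 1. Set side by side, the two steps cannot be told apart, so the change carries over between these two cores without a measurable difference: the same change on two cores in this assay, a 1.1-fold lower number (0.03 log units; within the scatter) from compound 1 to compound 2 and a 1.5-fold higher number (0.18 log units; within the scatter) from compound 3 to compound 4, 1.6-fold (0.20 log units) apart, within the scatter of two such steps. This does not establish a rule for the series, since it rests on two cores and one assay, and steps this small could hide a modest dependence on the core.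

The compounds shown carry only 4-chlorophenyl or 2-bromophenyl on a double-bonded chain carbon bound to a double-bonded ring carbon, so what a phenyl group bearing an amine or a carboxylic acid would give there remains open. Also open, as far as these compounds go, is whether the same change would stay as small on a core other than these two.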